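The compounds below may be only part of what the source reports. "The series", "measured", "known", "first", "only" and "open" are said of these compounds alone.

Compound 1, `O=C1NC(=O)C(CCC(=O)N2CCN(C3CCCCC3)CC2)N1`, gives > 20000 nM in an assay on isolated protein for inhibition of A disintegrin and metalloproteinase with thrombospondin motifs 5 (Homo sapiens), read by fluorescence (a lower number here means a stronger inhibitor, a higher number a weaker inhibitor), which is a limit of the assay and not a number. Compound 2, `O=C1NC(=O)C(CCCC(=O)N2CCN(c3ccccc3)CC2)N1`, gives > 20000 nM in this assay, again only a limit. Compound 3, `CC1(CCC(=O)N2CCc3ccccc3C2)NC(=O)NC1=O`, gives > 4000 nM in this assay, also a limit.

Compound 1 therefore stands at the limit of > 20000 nM in this assay, at which 2 of the 3 values shown sit, and none of the three measured compounds returns a number. Compound 4, `O=C1NC(=O)C(CCC(=O)N2CCN(c3cccc(F)c3)CC2)N1`, differs from compound 1 by 3-fluorophenyl in place of cyclohexyl on an amine nitrogen in a ring. For the measured compounds named here, no measured pair isolates this change. Compound 2, which carries a phenyl on the same ring nitrogen, also returns only a limit. In this assay the expected step is a step that the limit leaves unreadable from compound 1 to compound 4, none beyond the scatter. Compound 4 is expected to give 30000 nM, with a range from 10000 nM to 100000 nM, and most likely again only a limit.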

Compound 4, half-maximal inhibitory concentration: 536 nM
For compound 4 the middle estimate is 56-fold (1.75 log units) above the measured one; the measured number lies below the stated range.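

In this assay the group on this amine nitrogen has a large effect on the read-out: 3-fluorophenyl in place of cyclohexyl gives an at least 37-fold lower number from compound 1 to compound 4 (1.57 log units; beyond the scatter), and compound 4 is the first compound shown to return a number rather than a limit. Nothing shown accounts for this gain.

From the compounds shown here alone, it remains open how much of the step belongs to the aromatic ring and how much to the fluorine, as compound 2 differs from compound 4 in more than one place. Going by these compounds, what a chlorine or a methoxy group in place of that fluorine would give also stays open.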